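Tolerance on Vero Cells: From Compound 3 to Compound 4

The source may report more compounds than this note shows. Statements on the series, on what has been measured and on what is new or still open speak of the compounds shown alone.

Measured compounds:
compound 1 `CC(=O)C[C@H]1O[C@@H](On2cc(CN3C(=O)/C(=N\Nc4cccc(Cl)c4)c4ccccc43)nn2)[C@H](OC(C)=O)[C@@H](OC(C)=O)[C@H]1OC(C)=O`: 87900 nM
compound 2 `CC1(C)O[C@H]2O[C@H](Cn3cc(CN4C(=O)/C(=N\Nc5ccc(Br)cc5)c5ccccc54)nn3)[C@H](O)[C@H]2O1`: 72900 nM
compound 3 `O=C1/C(=N\Nc2ccc(Br)cc2)c2ccccc2N1Cc1cn(O[C@@H]2O[C@H](CO)[C@H](O)[C@H](O)[C@H]2O)nn1`: 91500 nM

In an ADME assay on Vero cells (Chlorocebus sabaeus) for cytotoxicity, read by fluorescence and resazurin assay, with a stated time of 3 days (a lower number here means that less compound is tolerated, a higher number that more compound is tolerated), the three measured compounds sit close together. Compound 3 gives the highest of the three numbers, but its gap to compound 1 and to compound 2 is within the scatter, so no order among them can be claimed. Among the measured compounds shown here, the only single-site step measured, a 1.3-fold higher number from compound 2 to compound 3 (0.10 log units; within the scatter), changes the sugar part and leaves the read-out where it was.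

Compound 4 `O=C1/C(=N\Nc2cccc(Cl)c2)c2ccccc2N1Cc1cn(O[C@@H]2O[C@H](CO)[C@H](O)[C@H](O)[C@H]2O)nn1` differs from compound 3 at the aryl group: 3-chlorophenyl in place of 4-bromophenyl on an amine nitrogen. For the measured compounds named here, no measured step bears directly on this change. Going by the values given here, compound 1 does carry the 3-chlorophenyl group, but it also carries a different sugar, so its pair with compound 3 shows only that both values lie within the scatter of each other. Among the compounds with values here, with the one measured step showing no movement and the three values clustered, the expectation for compound 4 is no step beyond the scatter, a 1.0-fold lower number from compound 3 to compound 4 (0.01 log units; within the scatter).

Compound 4 is therefore estimated at 90000 nM in this assay, with a range from 45000 nM to 180000 nM.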

Compound 4, half-maximal cytotoxic concentration: 84500 nM
Compound 4: middle estimate off by 1.1-fold (0.03 log units), on the high side, and the stated range covers the measured number.
By their numbers in this assay, from the lowest: compounds 2, 4, 1 and 3 (each within the scatter of the next).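

In this assay, among the compounds shown here, the exchange of 3-chlorophenyl for 4-bromophenyl on an amine nitrogen, with the rest of the molecule unchanged, gives a 1.1-fold lower number from compound 3 to compound 4 (0.03 log units; within the scatter) and so provides the first direct reading at this position, which the earlier compounds could not give, since no two of them differed at the aryl group alone. This single exchange alters both the halogen and its place on the ring, yet the two numbers remain within the scatter of each other, so the two effects cannot be told apart and neither can be said to matter here. Both single-site steps now shown stay within the scatter, the other being a 1.3-fold higher number from compound 2 to compound 3 (0.10 log units; within the scatter) and no compound shown goes against this, although two steps make a narrow basis; no evidence from any other kind of measurement bears on this result.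

The compounds shown carry only a bromine or a chlorine on this phenyl ring, so it remains open whether an unsubstituted phenyl, a methoxyphenyl or a carboxylic acid on the ring would stay in the same range. Also open, on these data alone, is whether the aryl exchange would read the same on the sugar part of compound 2.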